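This account rests on a few compounds, and the source may have more. Where it says the series, first, only, none or still open, it means among the compounds named here.

Of the compounds shown here, two have been measured in a functional assay on the whole organism with Rattus norvegicus as the target, with a stated time of 18 h, at a dose of 3 mg/kg by the oral route; a lower number here means a stronger effect, a higher number a weaker effect of the compound at the dose given. Compound 1, with the structure `CC1(C)C[C@@H](NC(=O)c2cn[nH]c2)c2cc(-c3ccc(Cl)cc3)c(-c3ccc(Cl)cc3Cl)nc2O1`, gives -3% in this assay and stands highest of the two numbers. Compound 2, with the structure `CC1(C)CC(NC(=O)C(C)(O)C(F)(F)F)c2cc(-c3ccc(Cl)cc3)c(-c3ccc(Cl)cc3Cl)nc2O1`, gives -27% in this assay, a value that lies lower than that of compound 1 by more than the usual scatter of repeated measurements.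

Compound 3, with the structure `CCc1cc(C(=O)N[C@@H]2CC(C)(C)Oc3nc(-c4ccc(Cl)cc4Cl)c(-c4ccc(Cl)cc4)cc32)n[nH]1`, has not yet been measured in this assay. It differs from compound 1 by a single change: 5-ethyl-1H-pyrazol-3-yl in place of 1H-pyrazol-4-yl on a carbonyl carbon. Going by the values given here, no measured pair in this set shows what a change of this kind does to the activity read-out, so the direction is open; a modest step is expected, one that may well stay within the scatter of the assay. Compound 3 is estimated to give -10% in this assay, within a range from -35% to 15%, which is an expected step of a number 7 percentage points lower from compound 1 to compound 3 (within the scatter).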

Compound 3, a percentage reported as activity, at one dose (the size of the read-out at that dose, not a potency): -48%
Estimate against measurement, compound 3: 38 percentage points above, and the stated range ends above it.
By their numbers in this assay, from the lowest: compound 3; then compound 2; then compound 1.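

In this assay, 5-ethyl-1H-pyrazol-3-yl in place of 1H-pyrazol-4-yl on the carbonyl carbon brings a number 45 percentage points lower from compound 1 to compound 3 (beyond the scatter), so the read-out at this dose depends strongly on which pyrazole sits at this place. The two groups have the same ring type and the same counts of hydrogen-bond donors and acceptors, so a large step can arise here without a change in those counts. Nothing available here explains the size of this step.

The change alters both the point of attachment and the ethyl group at once, so the compounds shown do not separate the two. An unsubstituted 1H-pyrazol-3-yl would address that, while 5-methyl-1H-pyrazol-3-yl or 5-propyl-1H-pyrazol-3-yl would show how the read-out follows the length of the chain.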